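Chloro Added to the Anilide of Compound 2

A few compounds are considered here, and "the series" means these few. Any claim that something is new, unique, unknown or untested is made for them only; others in the source may bear on it.

The study measured three compounds in a functional assay on SW480 cells (Homo sapiens) for cytotoxicity, read by MTT assay, with a stated time of 48 h; on this read-out higher numbers stand for weaker inhibition and lower numbers for stronger inhibition. Compound 1, `CCOC(=O)C1(C(=O)Nc2ccccc2)CC1c1cc(OC)c(OC)c(OC)c1`, was tested more than once, and in this assay compound 1 gives 49000 nM; > 100000 nM (2 entries), a set of several entries (the several entries of compound 1 in this assay, 49000 nM; > 100000 nM (2 entries)). Compound 3, `COc1cc([C@H]2C[C@@]2(CO)C(=O)NCc2ccc(C)cc2)cc(OC)c1OC`, reaches only a limit: in this assay compound 3 gives > 100000 nM. Compound 2, `CCOC(=O)[C@]1(C(=O)Nc2ccccc2)C[C@H]1c1cc(OC)c(OC)c(OC)c1`, likewise gives in this assay only the limit > 100000 nM. Compound 2 thus stands at the limit at which two of the three values shown sit (the limit of > 100000 nM in this assay, at which 2 of the 3 values shown sit); it differs from compound 1 in being drawn with a defined configuration where compound 1 is not (the fact that one of compounds 1 and 2 is drawn with a defined configuration and the other without, at the place where they differ), so nothing beyond their two values can be said of that pair.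

The unmeasured compound 4, `CCOC(=O)[C@]1(C(=O)Nc2ccccc2Cl)C[C@H]1c1cc(OC)c(OC)c(OC)c1`, differs from compound 2 in a single place: chloro in place of hydrogen on an aromatic carbon. Among the measured compounds shown here, no step between measured compounds is available to calibrate this change, and every value is either weak or a limit. The step from compound 2 to compound 4 is therefore expected to be a number no higher from compound 2 to compound 4 (the limit leaves the size open), none beyond the scatter. Compound 4 is estimated to give 100000 nM in this assay, within 40000 nM to 250000 nM, most likely reported again as a limit.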

Compound 4, half-maximal inhibitory concentration: 25600 nM
Estimate against measurement, compound 4: 3.9-fold (0.59 log units) above; the measured number lies below the stated range.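

Before compound 4, the series held no step between measured compounds that differ in one place, so nothing showed whether the anilide ring had any bearing on the read-out. In this assay, the change from phenylcarbamoyl to (2-chlorophenyl)carbamoyl, with chloro on an aromatic carbon ortho to a large group, gives an at least 3.9-fold lower number from compound 2 to compound 4 (0.59 log units; beyond the scatter), so this position responds to a single added heavy atom. For compound 2 the value > 100000 nM is a limit and not a number, which leaves the full size of the step unknown, and it is not the only value of its kind in the series: the limit of > 100000 nM in this assay, at which 2 of the 4 values shown sit.

The compounds shown leave open whether the step belongs to chloro itself or would also follow from another group at the same place, such as fluoro, methyl, methoxy or an amine, and whether chloro would act alike at another carbon of the ring. They also leave open whether the same change would carry over to a compound with a different core, such as compound 3.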